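This account rests on a few compounds, and the source may have more. Where it says the series, first, only, none or still open, it means among the compounds named here.

Measured in a functional assay on BV-2 cells (Mus musculus) for inhibition, read by Griess assay, with stated times of 3 h and 24 h; on this read-out lower numbers stand for stronger inhibition and higher numbers for weaker inhibition:
- compound 1 `O=S(=O)(/C=C/c1ccc(O)c(O)c1)CCCc1ccccc1`: 10500 nM
- compound 2 `[O-][S+](/C=C/c1ccc(O)c(O)c1)Cc1ccccc1`: 50300 nM
- compound 3 `[O-][S+](/C=C/c1ccc(O)c(O)c1)CCCc1ccccc1`: 28600 nM

Compound 2 stands at the highest of the three numbers in this assay. Its nearest neighbour is compound 3, whose number is lower by a gap that sits within the scatter, so no order between compound 2 and compound 3 can be read from these two values. Compound 1 lies furthest away, with a number lower by a gap beyond the scatter.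

Compound 4 `CC(C)(C)c1ccc(C[S+]([O-])/C=C/c2ccc(O)c(O)c2)cc1` differs from compound 2 in one place: tert-butyl in place of hydrogen on an aromatic carbon. Within the data shown here, no step between measured compounds isolates such a change, and the benzyl-to-phenylpropyl comparison between compound 2 and compound 3 shows only a gap within the scatter. The step from compound 2 to compound 4 in this assay is therefore expected to be small, toward a lower number at most, and possibly none beyond the scatter a 2.0-fold lower number from compound 2 to compound 4 (0.30 log units; within the scatter). Compound 4 is estimated at 25000 nM, with a range from 8000 nM to 80000 nM.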

Compound 4, half-maximal inhibitory concentration: 9300 nM
For compound 4 the middle estimate is 2.7-fold (0.43 log units) above the measured one; low and high end bracket the measured number.
By their numbers in this assay, from the lowest: compounds 4 and 1 (each within the scatter of the next); then compounds 3 and 2 (each within the scatter of the next).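

In this assay, tert-butyl in place of hydrogen on an aromatic carbon, para to a large group, gives a 5.4-fold lower number from compound 2 to compound 4 (0.73 log units; beyond the scatter) and is the first change shown at this position. The step is modest but beyond the scatter, so the position is not silent. A group of 4 carbon atoms, with no hydrogen-bond donors or acceptors, is tolerated there and gives a lower number rather than a loss of inhibition. No measurement shown bears on the origin of this step.

From the compounds shown here alone, one substituent at one position gives no trend, so whether a methyl group, a methoxy group, an amine or a carboxylic acid on the same carbon would move the number the same way remains open. Going by these compounds, it also remains open whether tert-butyl has a comparable effect on the phenylpropyl sulfoxide compound 3 or the sulfone compound 1.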